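The source may hold more compounds than are shown below. What is called first, only, known or untested is meant among the compounds shown, and "the series" means these compounds.

Compound 2 `C=CCc1cc(C(C)=O)c(O)cc1OCCCC` gives 32% in an assay on isolated protein for inhibition of leukotriene B4 receptor 1 (Homo sapiens), tested at 10 uM (a lower number here means less inhibition, a higher number more inhibition at the concentration tested (going by the name of the read-out)), the lowest of the three measured values. Compound 1 `CCc1cc(C(C)=O)c(O)cc1OCCCC(C)(C)C#N` reaches 85% in this assay, and compound 3 `CCc1cc(C(C)=O)c(O)cc1OCCCCCC[S+](C)[O-]` reaches 92%. Going by the values given here, the one measured single-point step, a number 7 percentage points higher from compound 1 to compound 3 (within the scatter), exchanges one group at the far end of the chain for another. Compound 4 `C=CCc1cc(C(C)=O)c(O)cc1OCCCCCC(=O)NO` differs from compound 2 by (hydroxycarbamoyl)methyl in place of hydrogen on a saturated chain carbon, four bonds along the chain from an oxygen on an aromatic ring. Among the compounds with values here, no measured step adds a group to a plain chain on this core, so the step from compound 1 to compound 3 bears on it only loosely, although compounds 1 and 3, which both carry a group at the end of the chain, read far higher than compound 2. A rise is therefore expected for compound 4. Compound 4 is estimated at 60%, in a range from 35% to 85%. The expected step is a number 28 percentage points higher from compound 2 to compound 4 (beyond the scatter).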

Compound 4, a percentage reported as inhibition, at one concentration (the size of the read-out at that concentration, not a potency): 85%
Beside the measured number, compound 4's estimate is 25 percentage points below it; measured number inside the range.
By their numbers in this assay, from the lowest: compound 2; then compounds 1, 4 and 3 (each within the scatter of the next).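

Adding (hydroxycarbamoyl)methyl to the plain chain of compound 2 gives a number 53 percentage points higher from compound 2 to compound 4 (beyond the scatter) in this assay, the first direct measure of a group added at this position on this core. The number at this concentration therefore responds strongly to this change at this saturated chain carbon. Nothing measured here explains the rise.

Going by these compounds, it remains open whether a carboxylic acid or a simple amide in place of the hydroxycarbamoyl end would read alike. On these data alone, it is also open whether a plain longer chain alone would give part of this step.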